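Moving One Small Group on a Carbonyl Carbon

The source may hold more compounds than are shown below. What is called first, only, known or untested is meant among the compounds shown, and "the series" means these compounds.

Of the compounds shown here, two with a shared core have so far been tested in a functional assay on the whole organism with Mus musculus as the target (a higher number here means that more compound is needed for the effect, a lower number that less compound is needed), on whole mice. Compound 1 `CC[C@@H](C(=O)Nc1ccccc1)N1CCCC1=O` gives 560 umol/kg in this test, and compound 2 `CC[C@@H](C(=O)N(C)O)N1CCCC1=O` gives 1000 umol/kg in the same test. These two numbers lie within the usual scatter of repeated measurements, so the data do not separate compound 2 from compound 1.

Compound 3 `CC[C@@H](C(=O)NOC)N1CCCC1=O` has the same atoms as compound 2, joined differently. It carries methoxyamino in place of hydroxy(methyl)amino on a carbonyl carbon. For the measured compounds named here, no pair of measured compounds isolates this kind of swap, so its effect cannot be read directly from the data. Going by the values given here, the only guide is that compound 1 at 560 umol/kg and compound 2 at 1000 umol/kg are not told apart by this assay despite carrying different groups at this place. No step beyond the scatter is therefore expected. The estimated step of a 1.3-fold lower number from compound 2 to compound 3 (0.10 log units; within the scatter) is small and stays within that scatter. For compound 3 the estimated value is 800 umol/kg with 300 umol/kg to 2000 umol/kg as its expected range.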

Compound 3, dose for half-maximal effect: 1000 umol/kg
Estimate against measurement, compound 3: 1.3-fold (0.10 log units) below; measured number inside the range.
By their numbers in this assay, from the lowest: compounds 1, 2 and 3 (each within the scatter of the next).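

In this assay the same atoms joined differently, methoxyamino in place of hydroxy(methyl)amino on a carbonyl carbon, give no change at the digits printed from compound 2 to compound 3 (within the scatter) and so leave no visible mark on the dose needed in whole mice. The second step, methoxy in place of phenyl on an amide-type nitrogen, gives a 1.8-fold higher number from compound 1 to compound 3 (0.25 log units; within the scatter) and so is also not told apart by this test, which means that neither rearranging these atoms nor this larger exchange of groups has yet shifted the number beyond the scatter. No accompanying measurement offers an explanation for this flat picture.

What the three compounds leave open is whether any group at this place can move the number beyond the scatter, for example a carboxylic acid on the carbonyl carbon, or a longer chain such as ethoxy or butoxy on the amide-type nitrogen. The rest of the shared core is identical in all three compounds, so they also give no information on how changes elsewhere in the molecule would affect the dose needed.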